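Phenyl ester series: dropping the propanoyl of compound 2

A few compounds are considered here, and "the series" means these few. Any claim that something is new, unique, unknown or untested is made for them only; others in the source may bear on it.

Within the data shown here, compound 2 `CCC(=O)c1ccccc1OC(=O)c1coc(-c2ccccc2)n1` gives 8.7% in an ADME assay on microsomes from liver (Rattus norvegicus, strain Sprague-Dawley) for metabolic stability, read by LC-MS, with a stated time of 15 min, tested at 20 uM (on this read-out lower numbers stand for a less stable compound and higher numbers for a more stable compound), the lowest of the three numbers measured so far. Compound 3 `O=C(Oc1ccc(Cl)cc1Cl)c1coc(-c2ccccc2)n1` gives 17.3% in this assay, which lies within the scatter of compound 2. Compound 1 `Cc1ccn2c(C(=O)NCc3ccc(Cl)cc3)c(C)nc2c1`, built on a different core, gives 80.7% in this assay, a gap to compound 2 that lies beyond the scatter. Compound 4 `O=C(Oc1ccccc1)c1coc(-c2ccccc2)n1` has not been measured. It differs from compound 2 by hydrogen in place of propanoyl on an aromatic carbon. Among the measured compounds shown here, no step between measured compounds matches this change. Compound 2 and compound 3 both sit low in this assay, and compound 4 is expected to stay in that region, so the step of a number 5.3 percentage points higher from compound 2 to compound 4 (within the scatter) is expected to be small and probably within the scatter. Compound 4 is therefore estimated at 14% in this assay, with a range from 3% to 38%.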

Compound 4, percent of the compound remaining: 0.2%
Estimate against measurement, compound 4: 13.8 percentage points above, and the stated range ends above it.
By their numbers in this assay, from the lowest: compounds 4, 2 and 3 (each within the scatter of the next, the first and the last beyond it); then compound 1.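

Hydrogen in place of propanoyl on an aromatic carbon, ortho to a large group, gives a step of a number 8.5 percentage points lower from compound 2 to compound 4 (within the scatter) in this assay. Compound 2 and compound 4 therefore sit in one low region, and the low number of compound 2 does not depend on the propanoyl. Unlike the earlier comparisons, this pair differs in one place and isolates this position.

As far as these compounds go, whether an amine, a carboxylic acid or a longer chain at this position would give a number beyond the scatter of compound 4 remains open. Nothing available bears on why this pair sits so low.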